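From methoxy to methoxymethoxy on a shared core

The source may report more compounds than this note shows. Statements on the series, on what has been measured and on what is new or still open speak of the compounds shown alone.

In a functional assay on J774.A1 cells (Mus musculus) for inhibition, read by Griess assay, with stated times of 1 h and 24 h (on this read-out higher numbers stand for weaker inhibition and lower numbers for stronger inhibition), compound 1 `O=C1CC(c2ccccc2OCc2ccccc2)Oc2ccccc21` gives 23200 nM and compound 2 `COc1ccccc1C1CC(=O)c2ccccc2O1` gives 44500 nM. Going by the values given here, the two numbers lie within the scatter of each other, so compound 2 cannot be ranked against its only measured neighbour. Compound 3 `COCOc1ccccc1C1CC(=O)c2ccccc2O1` differs from compound 2 as follows: methoxy in place of hydrogen on a saturated chain carbon bound to an oxygen on an aromatic ring. In words, it carries methoxy in place of hydrogen on a saturated chain carbon bound to an oxygen on an aromatic ring. Among the compounds with values here, one measured step bears on this place, a 1.9-fold higher number from compound 1 to compound 2 (0.28 log units; within the scatter). That step exchanges phenyl for hydrogen on the same carbon and stays within the scatter. The new methoxy occupies the spot where compound 1 has phenyl and compound 2 has hydrogen, so a value near these two is the reasonable expectation in this assay. No step beyond the scatter is expected, and the data support no firm direction. The expected change is a 1.3-fold lower number from compound 2 to compound 3 (0.13 log units; within the scatter), which would stay within the scatter. For compound 3 the estimated value is 33000 nM, with an expected range of 15000 nM to 75000 nM.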

Compound 3, half-maximal inhibitory concentration: 35200 nM
The estimate for compound 3 lay 1.1-fold (0.03 log units) below the measured number; the measured number falls inside the stated range.
By their numbers in this assay, from the lowest: compounds 1, 3 and 2 (each within the scatter of the next).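

The exchange of hydrogen for methoxy on the saturated chain carbon bound to an oxygen on an aromatic ring gives a 1.3-fold lower number from compound 2 to compound 3 (0.10 log units; within the scatter) in this assay, and the exchange of phenyl for methoxy on that same carbon gives a 1.5-fold higher number from compound 1 to compound 3 (0.18 log units; within the scatter). With three different substituents now compared at this place, hydrogen, methoxy and phenyl, every pair of compounds lies within the scatter, so this read-out separates none of them and gives no direction for the change from methoxy to methoxymethoxy. No independent evidence bears on this result.

Going by these compounds alone, what remains open is whether any group on this carbon can move the number beyond the scatter in this assay, since the three compounds give no step of that size to build on. An amine, a carboxylic acid or a longer chain in this place would test that, and the shared core, which is the same in all three compounds, leaves open whether the same flat picture would hold on a different core.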